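Cyclohexanol in place of cyclobutanol on the shared core

The source may hold more compounds than are shown below. What is called first, only, known or untested is meant among the compounds shown, and "the series" means these compounds.

Compound 1 `N#Cc1cnc(NCc2cnccc2C(F)(F)F)cc1N[C@H]1C[C@H](O)C1` gives 900 nM in an assay on isolated protein for inhibition of protein kinase C theta type (Homo sapiens), read by TR-FRET, with a stated time of 2 h (a higher number here means a weaker inhibitor, a lower number a stronger inhibitor), the highest of the three numbers in hand. Compound 3 `N#Cc1cnc(NCc2cncnc2C(F)(F)F)cc1N[C@H]1CC[C@@H](O)CC1`, in this assay, gives 450 nM, a gap from compound 1 that sits within the scatter. Compound 2 `N#Cc1cnc(NCc2ccccc2C(F)(F)F)cc1N[C@H]1C[C@@H](C(N)=O)C1`, in this assay, gives 150 nM, a gap that lies beyond the scatter. Compound 4 `CC1(C)C[C@H](Nc2cc(NCc3cnccc3C(F)(F)F)ncc2C#N)CC[C@H]1O` is not yet measured. It differs from compound 1 in one place: 4-hydroxy-3,3-dimethylcyclohexyl in place of 3-hydroxycyclobutyl on a nitrogen on an aromatic ring. Among the compounds with values here, no measured pair isolates this change. The expectation is a modest step towards stronger inhibition, a 2.3-fold lower number from compound 1 to compound 4 (0.35 log units; beyond the scatter), since compound 3, also carrying a hydroxycyclohexyl, gives 450 nM. Compound 4 is estimated at 400 nM in this assay, with a range from 120 nM to 1500 nM.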

Compound 4, half-maximal inhibitory concentration: 100 nM
The estimate for compound 4 lay 4.0-fold (0.60 log units) above the measured number; the whole stated range lies above it.
By their numbers in this assay, from the lowest: compounds 4 and 2 (each within the scatter of the next); then compounds 3 and 1 (each within the scatter of the next).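

Within the data shown here, on this nitrogen on an aromatic ring, 4-hydroxy-3,3-dimethylcyclohexyl in place of 3-hydroxycyclobutyl gives a 9.0-fold lower number from compound 1 to compound 4 (0.95 log units; beyond the scatter) in this assay and is the first change here isolated in one place. The group on this nitrogen therefore moves the number beyond the scatter, while the hydrogen-bond donor and acceptor counts stay the same. No measurement bears on the reason for this step.

The compounds shown do not separate the larger ring from the 3,3-dimethyl substitution. From the compounds shown here alone, whether an amine in place of the hydroxyl on this ring keeps the step also remains open.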